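The compounds below may be only part of what the source reports. "The series", "measured", "known", "first", "only" and "open" are said of these compounds alone.

In a functional assay on the whole organism (plasma, strain Sprague-Dawley) with Rattus norvegicus as the target, with a stated time of 2 h, at a dose of 12.5 mg/kg by the oral route (on this read-out lower numbers stand for a weaker effect and higher numbers for a stronger effect at the one dose given), compound 1 `c1ccc(C(/N=C2\CCCCCN2)C2CC2)cc1` gives 5%, and compound 2 `c1csc(C(/N=C2\CCCCCN2)C2CC2)c1` gives 33%. Going by the values given here, the single measured step so far is a number 28 percentage points higher from compound 1 to compound 2 (beyond the scatter). Compound 2 thus stands highest of the two numbers; its nearest neighbour is compound 1, whose number lies lower by a step beyond the scatter. Compound 3 `c1ccc(C(/N=C2\CCCCCN2)c2cccs2)cc1` differs from compound 2 by phenyl in place of cyclopropyl on a saturated chain carbon bound to an aromatic carbon and a double-bonded nitrogen. Among the compounds with values here, no measured step exchanges cyclopropyl for phenyl, and the one step known concerns another carbon and another pair of groups, so it bears only loosely on this change; the series gives no direct precedent. The expected step in this assay is therefore a number 3 percentage points lower from compound 2 to compound 3 (within the scatter), with no move beyond the scatter anticipated in either direction. For compound 3 the expected value in this assay is 30%, within a range from 5% to 60%.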

Compound 3, a percentage reported as inhibition, in the whole organism at one dose (the size of the read-out at that dose, not a potency): 23%
Beside the measured number, compound 3's estimate is 7 percentage points above it; low and high end bracket the measured number.
By their numbers in this assay, from the lowest: compound 1; then compounds 3 and 2 (each within the scatter of the next).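

In this assay, the step of a number 10 percentage points lower from compound 2 to compound 3 (within the scatter) shows that, with thiophen-2-yl present, a six-membered aromatic ring of carbon can replace the three-membered ring on a saturated chain carbon bound to an aromatic carbon and a double-bonded nitrogen without a move beyond the scatter. The step of a number 18 percentage points higher from compound 1 to compound 3 (beyond the scatter) adds a second case alongside a number 28 percentage points higher from compound 1 to compound 2 (beyond the scatter) in which thiophen-2-yl enters and the number rises beyond the scatter, whether phenyl or cyclopropyl is the group lost; neither compound 2 nor compound 3 goes against this. Nothing available accounts for either step.

Open, from the compounds shown here alone, is whether a methyl group, a longer chain or a primary amine in place of phenyl on this carbon would keep the read-out of compound 3. Also open, going by these compounds, is how a furan-2-yl ring would compare with thiophen-2-yl.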